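The source may hold more compounds than are shown below. What is called first, only, known or untested is meant among the compounds shown, and "the series" means these compounds.

Measured so far in an ADME assay on MT4 cells (Homo sapiens) for cytotoxicity, read by MTT assay, with a stated time of 4 days; a lower number here means that less compound is tolerated, a higher number that more compound is tolerated 
- compound 1 `Nc1ccc2oc(-c3ccc(F)cc3)c(O)c(=O)c2c1` gives 92600 nM 
- compound 2 `COc1ccc(-c2oc3ccc(N)cc3c(=O)c2OC)cc1` gives 200000 nM 
- compound 3 `COc1c(-c2cccc(F)c2)oc2ccc(N)cc2c1=O` gives 113000 nM 

All three compounds tolerate high concentrations in this assay. Compound 3, at 113000 nM, lies within the scatter of both other compounds, so its value cannot be ranked against either of them.

The next compound to be measured is compound 4 `COc1c(-c2ccc(F)cc2)oc2ccc(N)cc2c1=O`, which has the same atoms as compound 3 joined differently: 4-fluorophenyl in place of 3-fluorophenyl on an aromatic carbon. In words, 4-fluorophenyl stands in place of 3-fluorophenyl on an aromatic carbon, next to the ring oxygen and ortho to a methoxy group.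

Among the compounds with values here, the series holds no measured pair differing in one place, so there is no direct precedent for this change. The expectation therefore rests on the narrow spread of the three values and on the unchanged atom count of the swapped group. No step beyond the scatter is expected in this assay, in either direction. The expected size of the change is a 1.1-fold higher number from compound 3 to compound 4 (0.03 log units; within the scatter), which stays inside the scatter. For compound 4 the estimated value is 120000 nM, with an expected range of 60000 nM to 200000 nM as the likely bounds.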

Compound 4, half-maximal cytotoxic concentration: 141000 nM
Estimate against measurement, compound 4: 1.2-fold (0.07 log units) below; low and high end bracket the measured number.
By their numbers in this assay, from the lowest: compounds 1, 3, 4 and 2 (each within the scatter of the next, the first and the last beyond it).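

In this assay, within the data shown here, moving the fluorine from 3-fluorophenyl to 4-fluorophenyl on the aromatic carbon next to the ring oxygen gives a 1.2-fold higher number from compound 3 to compound 4 (0.10 log units; within the scatter), the first single-place reading at this position, and it shows no effect that can be told from the scatter. Among these compounds, compound 4 also supplies the first single-place readings for two other changes: fluoro in place of methoxy on an aromatic carbon gives a 1.4-fold lower number from compound 2 to compound 4 (0.15 log units; within the scatter), and methyl in place of hydrogen on an oxygen on an aromatic ring gives a 1.5-fold higher number from compound 1 to compound 4 (0.18 log units; within the scatter), so neither change separates the compounds in this assay. Nothing here offers an explanation for these readings.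

All three steps therefore describe a tolerance that stays flat across these small changes, but only for a fluoro or methoxy group on the phenyl ring and a hydroxyl or methoxy group on the shared core. From the compounds shown here alone, whether a carboxylic acid or a morpholine on that phenyl ring, or a longer alkoxy chain in place of the methoxy group on the core, would give a step beyond the scatter remains open.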